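Chloro to Bromo Exchange in a Two-Compound Series

The compounds below may be only part of what the source reports. "The series", "measured", "known", "first", "only" and "open" are said of these compounds alone.

Measured so far:
compound 1 `Cc1ccccc1-n1c(Nc2nc(-c3ccc(Br)cc3)cs2)n[nH]c1=S` — 30 mg/kg
compound 2 `Cc1ccc(-n2c(Nc3nc(-c4ccc(Cl)cc4)cs3)n[nH]c2=S)cc1` — 300 mg/kg

In a functional assay on the whole organism (strain Swiss albino) for inhibition, with Mus musculus as the target, with a stated time of 4 h (on this read-out higher numbers stand for an effect only at larger amounts of compound and lower numbers for an effect already at smaller amounts), compound 2 gives 300 mg/kg, the highest of the two numbers recorded. Its nearest neighbour, compound 1, gives 30 mg/kg in this assay, a gap well beyond the scatter. Among the measured compounds shown here, compound 1 and compound 2 differ in more than one place, so no single step connects them; the two values show only that compound 2 acts at the larger dose.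

Compound 3 `Cc1ccc(-n2c(Nc3nc(-c4ccc(Br)cc4)cs3)n[nH]c2=S)cc1` is not yet measured in this assay. It differs from compound 2 in one place: bromo in place of chloro on an aromatic carbon. The change is small in what it counts and leaves donors, acceptors and charge unchanged. Nothing measured isolates this exchange, since compound 1 carries bromo together with a different methylphenyl group. A modest step is expected in this assay from compound 2 to compound 3, a 1.5-fold lower number from compound 2 to compound 3 (0.18 log units; within the scatter), toward a smaller dose but possibly within the scatter. For compound 3 the expected minimum effective dose is 200 mg/kg, with a range from 60 mg/kg to 400 mg/kg.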

Compound 3, minimum effective dose: 300 mg/kg
The estimate for compound 3 lay 1.5-fold (0.18 log units) below the measured number; measured number inside the range.
By their numbers in this assay, from the lowest: compound 1; then compounds 2 and 3 (each within the scatter of the next).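

Working notes on the series: in this assay, the exchange of 4-chlorophenyl for 4-bromophenyl gives no change at the digits printed from compound 2 to compound 3 (within the scatter), so at this place, on an aromatic carbon para to a large group, this read-out does not separate chloro from bromo when 4-methylphenyl sits on the aromatic nitrogen. The other single change can now be read by itself: 4-methylphenyl in place of 2-methylphenyl on an aromatic nitrogen, with bromo held fixed, gives a 10-fold higher number from compound 1 to compound 3 (1.00 log units; beyond the scatter), so of the two steps available, only this one lies beyond the scatter. Nothing available here accounts for either step.

The compounds shown leave open whether the exchange of chloro for bromo reads the same when 2-methylphenyl sits on the aromatic nitrogen, as only one halogen appears with that group. They also leave open how this read-out responds to a group of another kind at the halogen's place, such as an amine, a methoxy group or a carboxylic acid.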